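Series notes: naphthalen-1-yl in place of phenyl on the carbonyl

The source may report more compounds than this note shows. Statements on the series, on what has been measured and on what is new or still open speak of the compounds shown alone.

Measured to date in a functional assay on A549 cells (Homo sapiens) for cytotoxicity, read by MTT assay, with a stated time of 48 h; on this read-out higher numbers stand for weaker inhibition and lower numbers for stronger inhibition:
- compound 1 `COc1cc(-c2nnc3n2NC(c2ccco2)C(C(=O)c2ccc(Br)cc2)S3)cc(OC)c1OC`: 42100 nM
- compound 2 `COc1cc(-c2nnc3n2NC(c2ccco2)C(C(=O)c2ccc(Cl)cc2)S3)cc(OC)c1OC`: 51400 nM
- compound 3 `COc1cc(-c2nnc3n2NC(c2ccco2)C(C(=O)c2ccccc2)S3)cc(OC)c1OC`: 33400 nM

The three compounds share one core and differ only at the ring on the carbonyl carbon. The steps of a 1.2-fold higher number from compound 1 to compound 2 (0.09 log units; within the scatter), a 1.3-fold lower number from compound 1 to compound 3 (0.10 log units; within the scatter) and a 1.5-fold lower number from compound 2 to compound 3 (0.19 log units; within the scatter) all lie within the scatter, so the three numbers stand together and compound 3, though it reads at the low end, cannot be set apart from compound 1 or compound 2.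

Compound 4 `COc1cc(-c2nnc3n2NC(c2ccco2)C(C(=O)c2cccc4ccccc24)S3)cc(OC)c1OC` is the next member, unmeasured. Its change from compound 3 is naphthalen-1-yl in place of phenyl on a carbonyl carbon. Going by the values given here, none of the measured steps makes this change; they swap bromo, chloro and hydrogen on the phenyl that now leaves, and each of them stayed within the scatter. The series thus gives no basis for a step beyond the scatter in either direction in this assay, and the expectation for compound 4 is a number near that of compound 3, with the range widened for the untested change: the step of a 1.1-fold lower number from compound 3 to compound 4 (0.05 log units; within the scatter) is expected to be small.

The estimate for compound 4 in this assay is 30000 nM, with a range from 12000 nM to 80000 nM.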

Compound 4, half-maximal inhibitory concentration: > 100000 nM
Compound 4: only a limit was reported; the forecaster's own chance of this, stated with the estimate: 15%; at least 3.3-fold (0.52 log units) between middle value and limit.
By their numbers in this assay, from the lowest: compounds 3, 1 and 2 (each within the scatter of the next). At a limit, above all of these: compound 4.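

In this assay compound 4 is reported only as a limit of the assay, not as a number: the limit of > 100000 nM in this assay, at which 1 of the 4 values shown sits.

Bromo, chloro and hydrogen on the phenyl gave steps within the scatter, whereas replacing the whole ring on the carbonyl carbon does move the reading: naphthalen-1-yl in place of phenyl gives an at least 2.9-fold higher number from compound 3 to compound 4 (0.47 log units; beyond the scatter), and naphthalen-1-yl in place of 4-bromophenyl gives an at least 2.3-fold higher number from compound 1 to compound 4 (0.37 log units; beyond the scatter). The comparison with the 4-chlorophenyl member, an at least 1.9-fold higher number from compound 2 to compound 4 (0.28 log units; that floor lies within the scatter), has a floor that lies within the scatter, so on its own it does not separate those two compounds. This position is therefore not indifferent to the group on the carbonyl carbon, though that reading rests on compound 4 alone.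

The limit leaves the true size of these steps open, and the compounds shown do not tell whether the second six-membered aromatic ring or the naphthalen-1-yl attachment counts. Also open, on these data alone, is whether naphthalen-2-yl, benzyl or 4-methoxyphenyl on the carbonyl carbon would read with compound 3 or with compound 4.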